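Hydroxy to dimethylamino: an unmeasured step

A few compounds are considered here, and "the series" means these few. Any claim that something is new, unique, unknown or untested is made for them only; others in the source may bear on it.

Compound 1, `CC1=CC[C@H](C(C)(C)NC(=S)N/N=C/c2ccccc2)CC1`: > 100000 nM (a limit)
Compound 2, `CC1=CC[C@H](C(C)(C)NC(=S)N/N=C/c2ccc(O)cc2)CC1`: > 100000 nM (a limit)

In a functional assay on NCI/ADR-RES cells (Homo sapiens) for inhibition, read by sulforhodamine B assay, with a stated time of 48 h (a lower number here means a stronger inhibitor of growth, a higher number a weaker inhibitor of growth), compound 1 reaches only a limit. Compound 2 likewise stands at a limit. The step that the two limits leave unreadable from compound 1 to compound 2 is therefore unreadable, since both values sit at the limit of > 100000 nM in this assay, at which 2 of the 2 values shown sit.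

Compound 3 `CC1=CC[C@H](C(C)(C)NC(=S)N/N=C/c2ccc(N(C)C)cc2)CC1` differs from compound 2 by dimethylamino in place of hydroxy on an aromatic carbon. Going by the values given here, the one measured step offers no readable size, so no direction can be taken from it. Compound 3 is thus expected to remain at the limit, the expected step of a number no higher from compound 2 to compound 3 (the limit leaves the size open) being nothing beyond the scatter. Compound 3 is estimated at 100000 nM, within 30000 nM to 300000 nM.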

Compound 3, concentration for total growth inhibition: > 100000 nM
Compound 3: a limit, no number; the forecaster's own chance of this, stated with the estimate: 80%; the middle value sits exactly at the limit.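

In this assay compound 3 gives > 100000 nM, which is a limit. Going by these compounds alone, no step among compound 1, compound 2 and compound 3 can therefore be read. The compounds shown leave open whether any of these aromatic substituents changes growth inhibition at all.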